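The source may hold more compounds than are shown below. What is called first, only, known or untested is meant among the compounds shown, and "the series" means these compounds.

Of the compounds shown here, three have so far been tested in a functional assay on the whole organism (strain Swiss) with Mus musculus as the target, in the maximal electroshock model, with a stated time of 2 h, at a dose of 300 mg/kg by the intraperitoneal route; a higher number here means a stronger effect of the compound at the dose given, a lower number a weaker effect. Compound 1 `COCC(C(=O)N1CCN(c2cccc(C(F)(F)F)c2)CC1)N1C(=O)CCC1=O` gives 100%. Compound 2 `CC(C(=O)N1CCN(c2ccccc2)CC1)N1C(=O)CCC1=O` gives 0%, and compound 3 `CCC(C(=O)N1CCN(c2ccccc2Cl)CC1)N1C(=O)CCC1=O` gives 0%. Compound 3 therefore stands level with compound 2 at the digits shown, the two together forming the bottom of the three numbers, while compound 1 lies far above both, well beyond the scatter.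

Compound 4 `CCC(C(=O)N1CCN(c2cccc(F)c2)CC1)N1C(=O)CCC1=O` has not yet been measured. It differs from compound 3 in a single place: 3-fluorophenyl in place of 2-chlorophenyl on an amine nitrogen in a ring. Within the data shown here, no step between two measured compounds matches this exchange, so its size cannot be read off directly. The readings already in hand span the whole range from no effect to full effect, so the step could be anything from none beyond the scatter to a large rise. On balance a moderate rise from compound 3 to compound 4 is expected, a number 30 percentage points higher from compound 3 to compound 4 (beyond the scatter). Compound 4 is estimated at 30%, with a range from 0% to 90%.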

Compound 4, a percentage reported as activity, at one dose (the size of the read-out at that dose, not a potency): 0%
Compound 4: the middle estimate sits 30 percentage points above what was measured, within the range that was stated.
By their numbers in this assay, from the lowest: compounds 2, 3 and 4 (each within the scatter of the next); then compound 1.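

In this assay, placing 3-fluorophenyl instead of 2-chlorophenyl on the amine nitrogen in the ring gives no change at the digits printed from compound 3 to compound 4 (within the scatter). This exchange moves the halogen-bearing group to a different printed position and swaps chlorine for fluorine, yet the reading stays at the bottom of the scale, so at this single dose the pair gives no sign that this place can turn on the effect. Nothing available explains this result.

Compound 1 differs from compound 4 in more than one place, so the compounds shown cannot tell which of those differences goes with its much higher reading. Also open, from the compounds shown here alone, is whether a methoxy group or a nitrile on the phenyl ring, with the rest of compound 4 kept the same, would give a reading above the bottom of the scale.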